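A Second Nitrile on the Phenol Ring

The source may report more compounds than this note shows. Statements on the series, on what has been measured and on what is new or still open speak of the compounds shown alone.

Compound 2 `N#Cc1cc(C(=O)N2CCc3ccccc32)ccc1O` gives 2500 nM in an assay on tissue (RPTEC cells) for inhibition of solute carrier family 22 member 12 (Homo sapiens), read by scintillation counting, with stated times of 15 min and 2 h (on this read-out lower numbers stand for stronger inhibition and higher numbers for weaker inhibition), the lowest of the two numbers recorded there; its nearest neighbour, compound 1 `Cc1c(C)n(C(=O)c2ccc(O)c(C#N)c2)c2ccccc12`, gives 10800 nM. Compound 3 `COc1cc(C(=O)N2CCc3ccccc32)cc(C#N)c1O` reaches only the limit of this assay, > 100000 nM, the limit (the limit of > 100000 nM in this assay, at which 1 of the 3 values shown sits). Among the measured compounds shown here, the step of an at least 40-fold higher number from compound 2 to compound 3 (1.60 log units; beyond the scatter) is the one measured change that bears on what follows. Compound 4 `N#Cc1cc(C(=O)N2CCc3ccccc32)cc(C#N)c1O` differs from compound 2 by cyano in place of hydrogen on an aromatic carbon. For the measured compounds named here, a cyano entering where a methoxy produced that large step suggests the number may rise again, though only one such step is known, so a more modest rise is expected, a 3.2-fold higher number from compound 2 to compound 4 (0.51 log units; beyond the scatter). Compound 4 is therefore estimated at 8000 nM, within 2000 nM to 40000 nM.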

Compound 4, half-maximal inhibitory concentration: 83900 nM
Compound 4: middle estimate off by 10-fold (1.02 log units), on the low side, outside the stated range (above it).
By their numbers in this assay, from the lowest: compound 2; then compound 1; then compound 4. At a limit, above all of these: compound 3.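

At this position, ortho to a hydroxy group, cyano in place of hydrogen proves nearly as costly as methoxy was: in this assay the change gives a 34-fold higher number from compound 2 to compound 4 (1.53 log units; beyond the scatter). So the earlier loss was not peculiar to methoxy. Compound 3 stands at a limit of the assay: the limit of > 100000 nM in this assay, at which 1 of the 4 values shown sits. Read against that limit, the swap gives an at least 1.1-fold lower number from compound 3 to compound 4 (0.07 log units; that floor lies within the scatter), which leaves cyano and methoxy unseparated.

Still open, going by these compounds, is whether any group at this position, such as a fluorine, an amine or a carboxylic acid, would keep the number of compound 2. Why two such different groups both raise it also remains unanswered.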